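A Larger Side Chain on Compound 3

The compounds below may be only part of what the source reports. "The series", "measured", "known", "first", "only" and "open" are said of these compounds alone.

In a functional assay on MCF7 cells (Homo sapiens) for antiproliferative activity, read by MTT assay, with a stated time of 48 h (on this read-out lower numbers stand for stronger inhibition and higher numbers for weaker inhibition), compound 1 `COC(=O)[C@H](C)NC(=O)c1ccc(Oc2nc3ccccc3nc2NC(C)(C)C)cc1` gives 38400 nM while compound 2 `CC[C@@H](C)[C@H](NC(=O)c1ccc(Oc2nc3ccccc3nc2NC(C)(C)C)cc1)C(=O)OC` gives 33400 nM and compound 3 `C[C@H](NC(=O)c1ccc(Oc2nc3ccccc3nc2NC(C)(C)C)cc1)C(=O)O` gives 29400 nM and so stands level with both of them within the scatter. Compound 4 `CC(C)C[C@H](NC(=O)c1ccc(Oc2nc3ccccc3nc2NC(C)(C)C)cc1)C(=O)O` departs from compound 3 by isopropyl in place of hydrogen on a saturated chain carbon, two bonds along the chain from an amide-type nitrogen and a carbonyl carbon and thus carries isopropyl in place of hydrogen on a saturated chain carbon, two bonds along the chain from an amide-type nitrogen and a carbonyl carbon. The closest measured change is sec-butyl in place of methyl on a saturated chain carbon bound to an amide-type nitrogen and a carbonyl carbon, which gives a 1.1-fold lower number from compound 1 to compound 2 (0.06 log units; within the scatter) and so nothing beyond the scatter. The other two measured steps, a 1.3-fold lower number from compound 1 to compound 3 (0.12 log units; within the scatter) and a 1.1-fold lower number from compound 2 to compound 3 (0.06 log units; within the scatter) alike, also stay within it. The step expected here is a 1.1-fold lower number from compound 3 to compound 4 (0.02 log units; within the scatter) in this assay and thus none beyond the scatter. Compound 4 is estimated at 28000 nM (expected range 14000 nM to 56000 nM).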

Compound 4, half-maximal inhibitory concentration: 40300 nM
Compound 4: middle estimate off by 1.4-fold (0.16 log units), on the low side; measured number inside the range.
By their numbers in this assay, from the lowest: compounds 3, 2, 1 and 4 (each within the scatter of the next).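

In this assay, isopropyl in place of hydrogen on a saturated chain carbon, two bonds along the chain from an amide-type nitrogen and a carbonyl carbon, gives a 1.4-fold higher number from compound 3 to compound 4 (0.14 log units; within the scatter), so the acid series, like the ester pair before it, shows no response to this side chain beyond the scatter. Replacing the whole group on the amide-type nitrogen gives a 1.2-fold higher number from compound 2 to compound 4 (0.08 log units; within the scatter) and a 1.0-fold higher number from compound 1 to compound 4 (0.02 log units; within the scatter), so 1-carboxy-3-methylbutyl stands level with both ester groups, and all four compounds lie within the scatter of one another. No information is available that would account for this flat result.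

The compounds shown leave open whether an amine, a hydroxyl group or a phenyl ring on this chain carbon would move the number beyond the scatter. They also leave open whether a longer chain would do so.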